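Replacing the Cyano Group with Methoxy on the Benzyl Ether

This account rests on a few compounds, and the source may have more. Where it says the series, first, only, none or still open, it means among the compounds named here.

Compound 2 `N#Cc1ccccc1COc1ccc(-c2cc(CN3CCN(Cc4ccc(C(F)(F)F)cc4)CC3)no2)cc1` gives 5000 nM in a functional assay on Huh-7 cells (Homo sapiens) for antiproliferative activity, read by sulforhodamine B assay, with a stated time of 72 h (on this read-out higher numbers stand for weaker inhibition and lower numbers for stronger inhibition), and of the two numbers in hand it lies within the scatter of compound 1 `FC(F)(F)c1ccc(CN2CCN(Cc3cc(-c4ccc(OCc5ccc(Cl)cc5)cc4)on3)CC2)cc1`, which gives 4000 nM; the step from compound 1 to compound 2 is a 1.3-fold higher number from compound 1 to compound 2 (0.10 log units; within the scatter). Compound 3 `COc1cccc(COc2ccc(-c3cc(CN4CCN(Cc5ccc(C(F)(F)F)cc5)CC4)no3)cc2)c1` differs from compound 2 in that (3-methoxyphenyl in place of 2-cyanophenyl on a saturated chain carbon bound to an oxygen on an aromatic ring). Among the compounds with values here, the single measured step concerns a change at this same place and stayed within the scatter, so no movement beyond the scatter is expected here either. Compound 3 is therefore estimated at 4500 nM, between 2000 nM and 10000 nM. That estimate means an expected step of a 1.1-fold lower number from compound 2 to compound 3 (0.05 log units; within the scatter).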

Compound 3, half-maximal inhibitory concentration: 800 nM
Compound 3: the middle estimate sits 5.6-fold (0.75 log units) above what was measured; measured number below the stated range.
By their numbers in this assay, from the lowest: compound 3; then compounds 1 and 2 (each within the scatter of the next).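

The group at this place does matter in this assay even though the first change there stayed within the scatter. 3-Methoxyphenyl in place of 2-cyanophenyl gives a 6.3-fold lower number from compound 2 to compound 3 (0.80 log units; beyond the scatter) and 3-methoxyphenyl in place of 4-chlorophenyl gives a 5.0-fold lower number from compound 1 to compound 3 (0.70 log units; beyond the scatter) so compound 3 stands apart from both earlier compounds. No measurement in hand explains this gain.

As far as these compounds go, it remains open whether the gain follows the methoxy group itself or its place on the ring, which 4-methoxyphenyl would test. Also open, from the compounds shown here alone, is whether 3-hydroxyphenyl or 3-ethoxyphenyl would keep it.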